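The compounds below may be only part of what the source reports. "The series", "measured", "known", "first", "only" and "open" are said of these compounds alone.

In a functional assay on SN12C cells (Homo sapiens) for cytotoxicity, read by sulforhodamine B assay, with a stated time of 48 h, tested at 0.1 uM (a higher number here means a weaker effect of the compound at the concentration tested, a lower number a stronger effect), compound 1 `COc1cc(-c2cc(/C=C/C(=O)c3ccc(Cl)c(Cl)c3)[nH]n2)cc(OC)c1OC` gives 96%, compound 2 `COc1ccc(C(=O)/C=C/c2cc(-c3cc(OC)c(OC)c(OC)c3)n[nH]2)cc1OC` gives 94%, and compound 3 `COc1ccc(C(=O)/C=C/c2cc(-c3cc(OC)c(OC)c(OC)c3)n[nH]2)cc1` gives 96%. Compound 3 thus sits level with compound 1 at the digits shown, and compound 2 lies furthest from it, although a number 2 percentage points higher from compound 2 to compound 3 (within the scatter) and no change at the digits printed from compound 1 to compound 3 (within the scatter) both stay within the scatter. Compound 4 `COc1cc(-c2cc(/C=C/C(=O)c3ccc(F)c(F)c3)[nH]n2)cc(OC)c1OC` carries 3,4-difluorophenyl in place of 4-methoxyphenyl on a carbonyl carbon. The measured steps that bear on this are the earlier swaps of the aryl group on the same carbonyl carbon: no change at the digits printed from compound 1 to compound 3 (within the scatter) and a number 2 percentage points lower from compound 1 to compound 2 (within the scatter), neither of which moved this assay beyond its scatter, whether a dichloro or a methoxy pattern stood on that ring. On that basis the step from compound 3 to compound 4 is expected to be a number 1 percentage points lower from compound 3 to compound 4 (within the scatter), that is, no step beyond the scatter. Compound 4 is therefore estimated to give 95% in this assay, within a range from 86% to 103%.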

Compound 4, a percentage reported as activity, at one concentration (the size of the read-out at that concentration, not a potency): 94%
Beside the measured number, compound 4's estimate is 1 percentage points above it; measured number inside the range.
By their numbers in this assay, from the lowest: compounds 2, 4, 1 and 3 (each within the scatter of the next).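

In this assay, 3,4-difluorophenyl on the carbonyl carbon stays within the scatter of all three earlier aryl groups: a number 2 percentage points lower from compound 3 to compound 4 (within the scatter), no change at the digits printed from compound 2 to compound 4 (within the scatter) and a number 2 percentage points lower from compound 1 to compound 4 (within the scatter). Fluorine on this ring therefore extends the earlier picture, as this position has now taken four different aryl groups without any step beyond the scatter, so the read-out does not separate them at the concentration tested. Nothing available here explains this flat result.

On these data alone, whether an amine or a carboxylic acid on that aryl ring, or a longer chain in its place, would move the read-out beyond the scatter remains open. Since each compound is represented at a single concentration, the compounds also leave open whether these aryl groups would separate at other concentrations.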